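Semicarbazone aryl variation: from compound 3 to compound 4

The source may report more compounds than this note shows. Statements on the series, on what has been measured and on what is new or still open speak of the compounds shown alone.

Of the compounds shown here, three have been measured in a functional assay on HT-29 cells (Homo sapiens) for cytotoxicity, read by MTT assay, with a stated time of 72 h; on this read-out lower numbers stand for stronger inhibition and higher numbers for weaker inhibition. Compound 1 `CN(C)CCn1cnnc1-c1cc(Oc2ccc(NC(=O)N/N=C/c3ccc(O)cc3)cc2F)ccn1` gives 1920 nM. Compound 2 `CN(C)CCn1cnnc1-c1cc(Oc2ccc(NC(=O)N/N=C/c3cc(Br)c(O)c(Br)c3)cc2F)ccn1` gives 2670 nM. Compound 3 `CN(C)CCn1cnnc1-c1cc(Oc2ccc(NC(=O)N/N=C/c3c(O)ccc4ccccc34)cc2F)ccn1` gives 670 nM, the lowest of the three numbers; its nearest neighbour is compound 1 and its furthest is compound 2, both beyond the scatter. The two steps into compound 3 are a 2.9-fold lower number from compound 1 to compound 3 (0.46 log units; beyond the scatter) and a 4.0-fold lower number from compound 2 to compound 3 (0.60 log units; beyond the scatter), whereas a 1.4-fold higher number from compound 1 to compound 2 (0.14 log units; within the scatter) stays within the scatter.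

Compound 4 `COc1ccc(/C=N/NC(=O)Nc2ccc(Oc3ccnc(-c4nncn4CCN(C)C)c3)c(F)c2)c(OC)c1` is not yet measured. Its change from compound 3 is 2,4-dimethoxyphenyl in place of 2-hydroxynaphthalen-1-yl on a carbon with a double bond to nitrogen. Among the measured compounds shown here, the two informative steps both show that swapping a single hydroxy-bearing ring for the 2-hydroxynaphthalen-1-yl group lowers the number by a modest amount; compound 4 returns to a single ring, and the exchange of the hydroxy group for methoxy groups has no precedent here. The step is therefore expected to reverse that gain, giving a 2.8-fold higher number from compound 3 to compound 4 (0.45 log units; beyond the scatter). Compound 4 is expected to give about 1900 nM, within a range of 800 nM to 4500 nM.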

Compound 4, half-maximal inhibitory concentration: 1780 nM
Compound 4: middle estimate off by 1.1-fold (0.03 log units), on the high side; the range from low to high includes it.
By their numbers in this assay, from the lowest: compound 3; then compounds 4, 1 and 2 (each within the scatter of the next).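

In this assay, 2,4-dimethoxyphenyl on the carbon with a double bond to nitrogen does not keep the level reached with 2-hydroxynaphthalen-1-yl, giving (a 2.7-fold higher number from compound 3 to compound 4 (0.42 log units; beyond the scatter)). A single ring with no hydroxy group at all reads like the hydroxy-bearing single rings, with both (a 1.1-fold lower number from compound 1 to compound 4 (0.03 log units; within the scatter)) and (a 1.5-fold lower number from compound 2 to compound 4 (0.18 log units; within the scatter)), so among compound 1, compound 2 and compound 4 the substituents on the single ring show no separable effect. No measurement shown gives a cause for these steps.

From the compounds shown here alone, it remains open whether the lower number of compound 3 goes with the second aromatic ring or with the hydroxy group, and a 2-methoxynaphthalen-1-yl group at this place would separate the two. Going by these compounds, how an amine or a carboxylic acid on the single ring would read is also open.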